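The source may report more compounds than this note shows. Statements on the series, on what has been measured and on what is new or still open speak of the compounds shown alone.

Three compounds have been measured in a functional assay on HepG2 cells (Homo sapiens) for cytotoxicity, read by MTT assay, with a stated time of 72 h; on this read-out lower numbers stand for stronger inhibition of growth and higher numbers for weaker inhibition of growth:

Compound 1, `CS/C(=N\C(=O)c1ccno1)NC(=O)c1ccno1`, gives > 100000 nM, which is a limit of the assay and not a number.
Compound 2, `O=C(/N=C(/NC(=O)c1ccno1)[Se]Cc1ccccc1)c1ccno1`, gives 9120 nM.
Compound 3, `O=C(/N=C(/NC(=O)c1cc(-c2ccccc2)nc2ccccc12)[Se]Cc1ccccc1)c1cc(-c2ccccc2)nc2ccccc12`, gives 25800 nM.

Compound 2 and compound 1 share a core and differ in one place: a group of 2 heavy atoms (1 carbon, 1 sulfur; no ring) in place of a group of 8 heavy atoms (7 carbon, 1 selenium; one six-membered aromatic ring of carbon only), on a carbon with a double bond to nitrogen. This change gave an at least 10-fold higher number from compound 2 to compound 1 (1.04 log units; beyond the scatter). The full size of that step is open-ended, since compound 1 sits at the limit of > 100000 nM in this assay, at which 1 of the 3 values shown sits.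

Compound 3 carries a different core; how its core differs from that of compound 2 is not broken down here. Among the measured compounds, compound 3 stands at the highest number in this assay, with compound 2 the nearest to it.

Compound 4, `CS/C(=N\C(=O)c1cc(-c2ccccc2)nc2ccccc12)NC(=O)c1cc(-c2ccccc2)nc2ccccc12`, has not yet been measured. It relates to compound 3 exactly as compound 1 relates to compound 2: a group of 2 heavy atoms (1 carbon, 1 sulfur; no ring) in place of a group of 8 heavy atoms (7 carbon, 1 selenium; one six-membered aromatic ring of carbon only), on a carbon with a double bond to nitrogen. The place of the change is the same in words in both pairs, so this is the same change made a second time, on the core of compound 3 instead of the core of compound 2.

Because the same change from compound 2 to compound 1 gave an at least 10-fold higher number from compound 2 to compound 1 (1.04 log units; beyond the scatter), a step of a similar direction and size, a 7.8-fold higher number from compound 3 to compound 4 (0.89 log units; beyond the scatter), is expected from compound 3 to compound 4 in this assay. On that basis compound 4 is estimated at 200000 nM, with a likely range from 60000 nM to 800000 nM, and there is a fair chance that this assay reports only a limit for it. Whether the step is as large on this second core rests on a single measured example and remains to be seen.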

Compound 4, concentration for 50% growth inhibition: 6240 nM
Compound 4: middle estimate off by 32-fold (1.51 log units), on the high side; measured number below the stated range.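

In this assay, putting methylsulfanyl in place of the larger group with selenium and its aromatic ring gave a 4.1-fold lower number from compound 3 to compound 4 (0.62 log units; beyond the scatter), so this change did not act on the second core as it had on the core of compound 2, and the two steps point in opposite directions: the same change on two cores in this assay, an at least 10-fold higher number (1.04 log units; beyond the scatter) from compound 2 to compound 1 and a 4.1-fold lower number (0.62 log units; beyond the scatter) from compound 3 to compound 4, at least 45-fold (1.65 log units) apart, beyond the scatter of two such steps

Compound 1 gives > 100000 nM, which is a limit of the assay and not a number, so the step leading to it has a known direction but no known full size.

Within the data shown here, the result shows that, in this series, the outcome of this one change on one core cannot simply be carried over to another core, but with only two pairs it gives no rule for any further core and does not show what lies behind the difference.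

As far as these compounds go, in both pairs the selenium and the aromatic ring leave together, so it stays open which of them counts on each core, and a benzylsulfanyl or a methylselanyl group on a carbon with a double bond to nitrogen would pull the two apart. From the compounds shown here alone, it also stays open how a third core would respond to the same change.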